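Swapping the Chain-End Nitrile for a Methyltetrazole

The compounds below may be only part of what the source reports. "The series", "measured", "known", "first", "only" and "open" are said of these compounds alone.

Compound 1 `CCc1cc(C(C)=O)c(O)cc1OCCCCCC(C)(C)C#N` is the reference point. In an assay on isolated protein for binding affinity to leukotriene B4 receptor 1 (Homo sapiens), tested at 1 uM (on this read-out higher numbers stand for more inhibition at the one concentration tested (going by the name of the read-out) and lower numbers for less inhibition), compound 1 gives 53%, the highest of the three numbers measured, although the gap to compound 3 is within the usual scatter, so those two cannot be told apart. Compound 3 `CCc1cc(C(C)=O)c(O)cc1OCCCC(C)(C)C(=O)O` gives 43% in this assay, and compound 2 `CC(=O)c1cc(C(C)(C)C)c(OCCCCCC(C)(C)C#N)cc1O` gives 2%.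

Two steps are known. The change of tert-butyl for ethyl on the aromatic ring gave a number 51 percentage points lower from compound 1 to compound 2 (beyond the scatter), a large loss, but it concerns a different part of the molecule. The change at the far end of the chain, to 1-carboxy-1-methylethyl, gave a number 10 percentage points lower from compound 1 to compound 3 (within the scatter), within the scatter; this step is the one that bears on the question here, since compound 4 also alters the chain end.

Compound 4 `CCc1cc(C(C)=O)c(O)cc1OCCCCCC(C)(C)c1nnn(C)n1` differs from compound 1 as follows: 2-methyl-2H-tetrazol-5-yl in place of cyano on a saturated chain carbon bound to three saturated chain carbons. Because the chain-end change in a number 10 percentage points lower from compound 1 to compound 3 (within the scatter) stayed within the scatter, the step to compound 4 is expected to be small as well, a number 8 percentage points lower from compound 1 to compound 4 (within the scatter). Compound 4 is therefore estimated to give 45% in this assay, within a range of 20% to 70%.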

Compound 4, a percentage reported as inhibition, at one concentration (the size of the read-out at that concentration, not a potency): 66%
Compound 4: middle estimate off by 21 percentage points, on the low side; measured number inside the range.
By their numbers in this assay, from the lowest: compound 2; then compounds 3 and 1 (each within the scatter of the next); then compound 4.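

In this assay, the step to the tetrazole gave a number 13 percentage points higher from compound 1 to compound 4 (beyond the scatter), so a five-membered aromatic ring with 4 hetero atoms can take the place of cyano on this saturated chain carbon without any loss, and with a modest gain. The earlier change at the chain end, a number 10 percentage points lower from compound 1 to compound 3 (within the scatter), could not be told apart from no change at all, which makes this the only chain-end change among these compounds to move the number beyond the scatter, and it does so upward. Nothing available explains the gain, so the data show only that it occurs, not what lies behind it.

As far as these compounds go, it remains open whether a carboxylic acid, an amide or a tetrazole without the methyl group, placed on this same carbon, would give a similar number, and whether the gain would persist with tert-butyl in place of ethyl on the aromatic carbon. From the compounds shown here alone, each number also comes from a single concentration, so how far the gain reflects a difference in potency is still unknown.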